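Methoxymethylsulfanyl replaces diaminopropylsulfanyl on the shared core

The source may hold more compounds than are shown below. What is called first, only, known or untested is meant among the compounds shown, and "the series" means these compounds.

Three compounds share one core and differ only on the saturated chain carbon bound to a sulfur. Compound 1 `CC(C)c1n[nH]c2c(NCc3ccc(-c4ccccn4)cc3)nc(SCCNC(=N)N)nc12` gives 390 nM in a functional assay on HT cells (Homo sapiens) for antiproliferative activity, read by fluorescence, with a stated time of 72 h; on this read-out lower numbers stand for stronger inhibition of growth and higher numbers for weaker inhibition of growth. Compound 2 `CCC(O)CSc1nc(NCc2ccc(-c3ccccn3)cc2)c2[nH]nc(C(C)C)c2n1` gives 273 nM in this assay. Compound 3 `CC(C)c1n[nH]c2c(NCc3ccc(-c4ccccn4)cc3)nc(SCC(N)CN)nc12` gives 480 nM in this assay. Compound 3 sits at the upper end of the three numbers, yet both of its gaps are within the scatter: a 1.2-fold higher number from compound 1 to compound 3 (0.09 log units; within the scatter) and a 1.8-fold higher number from compound 2 to compound 3 (0.25 log units; within the scatter). The remaining pair behaves the same way, a 1.4-fold lower number from compound 1 to compound 2 (0.15 log units; within the scatter).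

Compound 4 `COCSc1nc(NCc2ccc(-c3ccccn3)cc2)c2[nH]nc(C(C)C)c2n1` is the next member. Relative to compound 3 the change is methoxy in place of 1,2-diaminoethyl on a saturated chain carbon bound to a sulfur. The 1,2-diaminoethyl group leaves and methoxy enters, at the same place where every measured step of the series has been made.

All three measured steps bear on this change, since each swaps the group on that chain carbon, and none of them moved the number beyond the scatter. Within the data shown here, no measured step covers methoxy itself, so the expectation rests on the pattern that this position has so far tolerated exchanges without a shift beyond the scatter. Compound 4 is therefore expected to show a step of a 1.3-fold lower number from compound 3 to compound 4 (0.10 log units; within the scatter) in this assay, that is, no movement beyond the scatter. The estimate for compound 4 in this assay is 380 nM, with a range of 160 nM to 900 nM.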

Compound 4, concentration for 50% growth inhibition: 340 nM
Estimate against measurement, compound 4: 1.1-fold (0.05 log units) above; measured number inside the range.
By their numbers in this assay, from the lowest: compounds 2, 4, 1 and 3 (each within the scatter of the next).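

In this assay, methoxy in place of 1,2-diaminoethyl on a saturated chain carbon bound to a sulfur gives no shift beyond the scatter (a 1.4-fold lower number from compound 3 to compound 4 (0.15 log units; within the scatter)), even though the entering group has 0 hydrogen-bond donors and no nitrogen. Methoxy also stays within the scatter when read against the other two groups, both for 1-hydroxypropyl (a 1.2-fold higher number from compound 2 to compound 4 (0.10 log units; within the scatter)) and for the group of 5 heavy atoms (a 1.1-fold lower number from compound 1 to compound 4 (0.06 log units; within the scatter)). Compound 4 is the only one of the four with no hydrogen-bond donor in the group at this place, yet the number for compound 4 cannot be separated from the other three, so a donor in this group is not required for a number in this range.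

No evidence is at hand on why this place accepts these exchanges.

Going by these compounds, it remains open whether a carboxylic acid, a phenyl ring or a longer alkyl chain at this place would also stay within the scatter. All the groups shown here have no ring, and the shared core is the same throughout, so the steps say nothing about changes elsewhere on it.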